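Removing the Phenyl from the Alkyne Tail

The source may hold more compounds than are shown below. What is called first, only, known or untested is meant among the compounds shown, and "the series" means these compounds.

Compound 2 `O=C1c2ccccc2C(=O)N1C/C=C/Cn1cc(C#CCCc2ccccc2)c(=O)[nH]c1=O` gives 44000 nM in a functional assay on L1210 cells (Mus musculus) for antiproliferative activity, read by MTT assay, with a stated time of 2 days (a higher number here means a weaker inhibitor, a lower number a stronger inhibitor), and this is the only number shown. Compound 1 `CCCCCC#Cc1cn(C/C=C/CN2C(=O)c3ccccc3C2=O)c(=O)[nH]c1=O` sits at the limit of > 500000 nM in this assay, at which 1 of the 2 values shown sits. Its value of > 500000 nM in this assay is a limit and not a number. Among the compounds with values here, the one measured step, an at least 11-fold lower number from compound 1 to compound 2 (1.05 log units; beyond the scatter), went in the opposite direction from the change now in question. Compound 3 `CCCCC#Cc1cn(C/C=C/CN2C(=O)c3ccccc3C2=O)c(=O)[nH]c1=O` differs from compound 2 by ethyl in place of phenyl on a saturated chain carbon, two bonds along the chain from a triple-bonded carbon. The present change is expected to undo much of the earlier gain, an estimated step of a 9.1-fold higher number from compound 2 to compound 3 (0.96 log units; beyond the scatter). Compound 3 is therefore expected to give about 400000 nM in this assay, with a range from 100000 nM to 3000000 nM, and with a fair chance that only a limit is reported.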

Compound 3, half-maximal inhibitory concentration: 236000 nM
Estimate against measurement, compound 3: 1.7-fold (0.23 log units) above; the measured number falls inside the stated range.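

The phenyl at this place now has a measured cost on its own: in this assay, ethyl in its place gives a 5.4-fold higher number from compound 2 to compound 3 (0.73 log units; beyond the scatter). Without any ring in the tail, the length of the chain also counts, as hydrogen in place of methyl on a saturated chain carbon, four bonds along the chain from a triple-bonded carbon, gives an at least 2.1-fold lower number from compound 1 to compound 3 (0.32 log units; beyond the scatter), so a tail without phenyl can still give a number. That step has only a lower bound, as compound 1 stands at a limit and not a number: the limit of > 500000 nM in this assay, at which 1 of the 3 values shown sits.

The compounds shown leave open whether a cyclohexyl would serve in place of the phenyl, or whether the ring itself is what counts. They also leave open how an amine or a carboxylic acid at the end of the chain, or a longer chain carrying the phenyl, would behave.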